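A chloro step from compound 2

The compounds below may be only part of what the source reports. "The series", "measured", "known", "first", "only" and "open" are said of these compounds alone.

compound 1 `[O-][n+]1onc2ccc(/C=C\[S+]([O-])c3ccc(Cl)cc3)cc21`: 10000 nM
compound 2 `O=C(/C=C/c1ccc2nonc2c1)c1ccccc1`: 102000 nM

In an ADME assay on J774 cells (Mus musculus) for cytotoxicity, read by MTT assay, with a stated time of 48 h (a lower number here means a stronger inhibitor, a higher number a weaker inhibitor), compound 2 gives 102000 nM, the higher of the two numbers. Compound 1 gives 10000 nM, and the gap between the two lies beyond the scatter. The next compound, compound 3 `O=C(/C=C/c1ccc2nonc2c1)c1ccc(Cl)cc1`, differs from compound 2 by one change: chloro in place of hydrogen on an aromatic carbon. In words, this is chloro in place of hydrogen on an aromatic carbon. Within the data shown here, no measured pair shows this change, so the expectation is loose: a modest move towards a lower number, only slightly beyond the scatter. The estimated change is a 1.7-fold lower number from compound 2 to compound 3 (0.23 log units; within the scatter). Compound 3 is expected at 60000 nM, with an estimated range of 20000 nM to 150000 nM.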

Compound 3, half-maximal inhibitory concentration: 251000 nM
Beside the measured number, compound 3's estimate is 4.2-fold (0.62 log units) below it; measured number above the stated range.
By their numbers in this assay, from the lowest: compound 1; then compound 2; then compound 3.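

In this assay the swap of hydrogen for chloro, on an aromatic carbon para to a large group, gives a 2.5-fold higher number from compound 2 to compound 3 (0.39 log units; beyond the scatter) and so moves the number up, towards a weaker inhibitor. Among these compounds, this is the only pair here that differs in one place, so it is the first direct reading of a single change on this ring. Nothing measured here explains the direction of this step.

Going by these compounds, whether a fluoro, a methoxy or an amine at this same place would move the number the same way remains open. So does whether chloro would act alike on the core of compound 1.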